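Amide tail variation on a fluorinated sulfoxide series

The source may report more compounds than this note shows. Statements on the series, on what has been measured and on what is new or still open speak of the compounds shown alone.

Measured compounds
compound 1 `CC1=C(C(C)C(=O)NCCN(C)C)c2cc(F)ccc2/C1=C\c1ccc([S+](C)[O-])cc1` — 12700 nM
compound 2 `CC1=C(C(C)C(=O)N(CCNC(C)C)C(C)C)c2cc(F)ccc2/C1=C\c1ccc([S+](C)[O-])cc1` — 8060 nM
compound 3 `CC1=C(C(C)C(=O)NCCN2CCCCC2)c2cc(F)ccc2/C1=C\c1ccc([S+](C)[O-])cc1` — 9670 nM

All three share one core and differ only in the amide tail. In a functional assay on HT-29 cells (Homo sapiens) for inhibition, read by CellTiter-Glo, with a stated time of 72 h (a lower number here means that less compound is tolerated, a higher number that more compound is tolerated), compound 1 gives 12700 nM, compound 2 gives 8060 nM and compound 3 gives 9670 nM. The steps among them are small: a 1.6-fold lower number from compound 1 to compound 2 (0.20 log units; within the scatter), a 1.3-fold lower number from compound 1 to compound 3 (0.12 log units; within the scatter) and a 1.2-fold higher number from compound 2 to compound 3 (0.08 log units; within the scatter). Compound 3 stands second highest of the three numbers, nearest to compound 2 and furthest from compound 1, both gaps within the scatter, so no ordering among the three is claimed.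

Compound 4 `CC1=C(C(C)C(=O)N2CCN(c3ccncc3)CC2)c2cc(F)ccc2/C1=C\c1ccc([S+](C)[O-])cc1` is the next member. Its change from compound 3: 4-(pyridin-4-yl)piperazin-1-yl in place of (2-(piperidin-1-yl)ethyl)amino on a carbonyl carbon. The measured steps all concern tails that keep an amide hydrogen and a basic amine two bonds along a chain; each was within the scatter. None of them exchanges the whole tail for a ring-linked arrangement without a hydrogen-bond donor, so the bearing of the three steps on this change is only indirect: they show that the tail has so far moved this assay little.

On that basis no step beyond the scatter is expected, with a wide range to allow for the larger change; the expected step is a 1.0-fold higher number from compound 3 to compound 4 (0.01 log units; within the scatter). For compound 4 the estimated value in this assay is 10000 nM, with a range of 3000 nM to 30000 nM.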

Compound 4, half-maximal cytotoxic concentration: 4990 nM
Beside the measured number, compound 4's estimate is 2.0-fold (0.30 log units) above it; the measured number falls inside the stated range.
By their numbers in this assay, from the lowest: compounds 4, 2, 3 and 1 (each within the scatter of the next, the first and the last beyond it).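

Among the steps in this assay, the change to 4-(pyridin-4-yl)piperazin-1-yl on the carbonyl carbon gives the first that lies beyond the scatter: a 2.5-fold lower number from compound 1 to compound 4 (0.41 log units; beyond the scatter), a modest step. The same tail stays within the scatter in the other two comparisons, a 1.9-fold lower number from compound 3 to compound 4 (0.29 log units; within the scatter) and a 1.6-fold lower number from compound 2 to compound 4 (0.21 log units; within the scatter), so compound 4 separates only from compound 1, and no order is claimed among compound 2, compound 3 and compound 4. Nothing measured on these compounds accounts for the step that separates compound 4 from compound 1.

The tail of compound 4 brings in a six-membered aromatic ring with 1 hetero atom, a six-membered non-aromatic ring with 2 hetero atoms and 0 hydrogen-bond donors all at once, so the compounds shown do not assign the step to any one of these features. A phenyl group in place of the pyridin-4-yl on the same piperazin-1-yl, or a morpholine amide with no second ring, would separate these features.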